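Indole replaced by trichlorophenyl on the core of compound 1

The source may report more compounds than this note shows. Statements on the series, on what has been measured and on what is new or still open speak of the compounds shown alone.

Measured so far in a functional assay on DU-145 cells (Homo sapiens) for inhibition, read by trypan blue exclusion, with a stated time of 96 h; on this read-out higher numbers stand for weaker inhibition of growth and lower numbers for stronger inhibition of growth:
compound 1 `Cc1ccc(S/C(=C/c2c[nH]c3ccccc23)C(=O)c2ccc(Cl)cc2)cc1` gives 10000 nM
compound 2 `O=C(/C(=C\c1c[nH]c2ccccc12)SCc1ccc(F)cc1)c1ccc(Cl)cc1` gives 1000 nM
compound 3 `Cc1ccc(S/C(=C/c2c[nH]c3ccc(Br)cc23)C(=O)c2ccc(Cl)cc2)cc1` gives 1000 nM

Compound 1 has the highest of the three numbers in this assay; both other compounds lie one step below it, with a 10-fold lower number from compound 1 to compound 2 (1.00 log units; beyond the scatter) and a 10-fold lower number from compound 1 to compound 3 (1.00 log units; beyond the scatter), each beyond the scatter.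

Compound 4 `Cc1ccc(S/C(=C/c2cc(Cl)cc(Cl)c2Cl)C(=O)c2ccc(Cl)cc2)cc1` carries 2,3,5-trichlorophenyl in place of 1H-indol-3-yl on a double-bonded chain carbon bound to a double-bonded chain carbon. Neither measured step touches this chain position: one altered the group on the sulfur, the other added a halogen on the bicyclic ring, and both lowered the number. For the measured compounds named here, no measured step therefore bears directly on this exchange, which is larger than either. The step is expected to be small, a 2.0-fold lower number from compound 1 to compound 4 (0.30 log units; within the scatter), with wide uncertainty.

Compound 4 is estimated at 5000 nM, within 1000 nM to 30000 nM.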

Compound 4, concentration for 50% growth inhibition: 50000 nM
Beside the measured number, compound 4's estimate is 10-fold (1.00 log units) below it; the measured number lies above the stated range.
By their numbers in this assay, from the lowest: compounds 2 and 3 (each within the scatter of the next); then compound 1; then compound 4.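

In this assay the position on a double-bonded chain carbon bound to a double-bonded chain carbon is not indifferent to exchange: 2,3,5-trichlorophenyl in place of 1H-indol-3-yl gives a 5.0-fold higher number from compound 1 to compound 4 (0.70 log units; beyond the scatter) and is the only step shown that raises the number. The exchange changes the ring nitrogen, the five-membered aromatic ring and the chlorines together, so no single feature can be singled out. Nothing shown accounts for this step.

On these data alone, whether a pyridine ring or an aminophenyl group at this position would restore growth inhibition remains open. Also open, as far as these compounds go, is whether the 4-fluorobenzyl exchange on sulfur would lower the number on the trichlorophenyl compound.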